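Aryl swaps on the thiophene core leave A3 displacement flat

A few compounds are considered here, and "the series" means these few. Any claim that something is new, unique, unknown or untested is made for them only; others in the source may bear on it.

Measured so far:
compound 1 `CC(C)(C)Cc1c(-c2ccc(Cl)cc2)sc(N)c1C(=O)c1ccc(Cl)cc1` gives 1%
compound 2 `Cc1cccc(-c2sc(N)c(C(=O)c3ccc(Cl)cc3)c2CC(C)(C)C)c1` gives 1%
compound 3 `Cc1noc(C)c1-c1sc(N)c(C(=O)c2ccc(Cl)cc2)c1CC(C)(C)C` gives 1%

In an assay on CHO cells for displacement of a labelled ligand from adenosine receptor A3 (Homo sapiens), read by scintillation counting, tested at 10 uM (a lower number here means less inhibition, a higher number more inhibition at the concentration tested (going by the name of the read-out)), compound 3 stands level with compound 1 and compound 2 at the digits shown; the nearest is compound 1, with no change at the digits printed from compound 1 to compound 3 (within the scatter), and the furthest is compound 2, with no change at the digits printed from compound 2 to compound 3 (within the scatter). Compound 4 `CC(C)(C)Cc1c(-c2cn[nH]c2)sc(N)c1C(=O)c1ccc(Cl)cc1` differs from compound 3 in one place: 1H-pyrazol-4-yl in place of 3,5-dimethyl-1,2-oxazol-4-yl on an aromatic carbon. Going by the values given here, the steps that bear on this are no change at the digits printed from compound 1 to compound 2 (within the scatter), no change at the digits printed from compound 1 to compound 3 (within the scatter) and no change at the digits printed from compound 2 to compound 3 (within the scatter), each a change of the group at the same aromatic carbon and none beyond the scatter. Because of no change at the digits printed from compound 1 to compound 3 (within the scatter) and no change at the digits printed from compound 2 to compound 3 (within the scatter), the step to compound 4 is expected to be none beyond the scatter, that is a number 1 percentage points higher from compound 3 to compound 4 (within the scatter). Compound 4 is therefore estimated at 2%, between -6% and 14%.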

Compound 4, a percentage reported as inhibition, at one concentration (the size of the read-out at that concentration, not a potency): 1%
Compound 4: middle estimate off by 1 percentage points, on the high side; the range from low to high includes it.
By their numbers in this assay, from the lowest: compounds 1, 2, 3 and 4 (each within the scatter of the next).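

In this assay the 1H-pyrazol-4-yl group brings 1 hydrogen-bond donor where 3,5-dimethyl-1,2-oxazol-4-yl has 0, and 5 heavy atoms against 7, yet the reading shows no change at the digits printed from compound 3 to compound 4 (within the scatter). Against the two aryl groups the picture is the same, with no change at the digits printed from compound 2 to compound 4 (within the scatter) and no change at the digits printed from compound 1 to compound 4 (within the scatter), so this aromatic carbon has now carried a ring with a hydrogen-bond donor without a shift beyond the scatter. Nothing available explains this flat result.

From the compounds shown here alone, whether an amine or a carboxylic acid at this carbon would alter the reading remains open. So does the effect of a shorter chain in place of the neopentyl group.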